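Anilide swap on the shared core: tolerability notes

A few compounds are considered here, and "the series" means these few. Any claim that something is new, unique, unknown or untested is made for them only; others in the source may bear on it.

Measured so far:
compound 1, `COc1ccc2c(=O)c(/C=C/C(=O)NCc3ccccc3F)coc2c1`: 146000 nM
compound 2, `COc1ccc2c(=O)c(/C=C/C(=O)Nc3ccccc3OC)coc2c1`: 1050000 nM

Going by the values given here, in an ADME assay on HepG2 2.2.15 cells (Homo sapiens) for cytotoxicity, read by MTT assay, with stated times of 48 h and 9 days (a lower number here means that less compound is tolerated, a higher number that more compound is tolerated), compound 2 gives 1050000 nM, the higher of the two numbers in hand; compound 1 is its nearest neighbour, and the step from one to the other, a 7.2-fold higher number from compound 1 to compound 2 (0.86 log units; beyond the scatter), is the only measured step.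

Compound 3, `COc1ccc2c(=O)c(/C=C/C(=O)Nc3ccc(Cl)cc3)coc2c1`, differs from compound 2 in one place: 4-chlorophenyl in place of 2-methoxyphenyl on an amide-type nitrogen. Among the compounds with values here, the single measured step bears on it only loosely, since it swapped both the link to the ring and the ring substituent at once, while the move to compound 3 keeps the direct attachment of the ring to the amide nitrogen and changes only the substituent. Within the data shown here, there is no measured pair that isolates a substituent change on that ring, so no direction can be read from the data; the change is expected to stay within or near the scatter, with a slight lean toward a lower number for compound 3, a 1.8-fold lower number from compound 2 to compound 3 (0.24 log units; within the scatter), as an estimate rather than a reading of any step. Compound 3 is therefore expected to show about 600000 nM in this assay, with a range of 200000 nM to 1500000 nM.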

Compound 3, half-maximal cytotoxic concentration: 272000 nM
For compound 3 the middle estimate is 2.2-fold (0.34 log units) above the measured one, within the range that was stated.
By their numbers in this assay, from the lowest: compounds 1 and 3 (each within the scatter of the next); then compound 2.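

In this assay, with the ring still attached directly to the amide-type nitrogen, the change of substituent alone gives a 3.9-fold lower number from compound 2 to compound 3 (0.59 log units; beyond the scatter), so the link to the ring is not the only feature tied to the number at this position. The step of a 1.9-fold higher number from compound 1 to compound 3 (0.27 log units; within the scatter) replaces 2-fluorobenzyl with 4-chlorophenyl and stays within the scatter, so removing the benzyl link does not by itself carry the difference seen with 2-methoxyphenyl, as compound 3 also lacks that link yet cannot be told apart from compound 1. No measured evidence in hand accounts for either step.

The swap from 2-methoxyphenyl to 4-chlorophenyl alters the substituent and its place on the ring together, so the compounds shown cannot say which of the two goes with the step from compound 2 to compound 3. Also open, going by these compounds, is how this position would respond to an amine or a carboxylic acid on the ring, or to a longer chain linking the ring to the amide-type nitrogen.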